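The compounds below may be only part of what the source reports. "The series", "measured", "known", "first", "only" and "open" are said of these compounds alone.

Measured so far:

- Compound 1 `CC(=O)c1ccc(/C=C2\CCCN=C2c2cccnc2)cc1`: in an assay on membranes from brain for displacement of a labelled ligand from Neuronal acetylcholine receptor; alpha4/beta2 (Rattus norvegicus), with a stated time of 3 h (a lower number here means a stronger inhibitor, a higher number a weaker inhibitor), compound 1 gives 4490 nM.
- Compound 2 `COc1ccc2cc(/C=C3\CCCN=C3c3cccnc3)ccc2c1`: in this assay compound 2 gives 600 nM.

Compound 1 holds the higher of the two numbers; compound 2 gives a value that lies well below it, and the gap between them is beyond the usual scatter. The two compounds differ in more than one place, so no single change can be read from that pair; it only shows that at least one member of the series binds considerably more tightly than compound 1.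

Compound 3 `COc1ccc(/C=C2\CCCN=C2c2cccnc2)cc1` is the next member, not yet measured. It differs from compound 1 in one place: methoxy in place of acetyl on an aromatic carbon. The group sits on the ring that carries the exocyclic double bond, para to a large group, as in compound 1.

Nothing in the measured pair isolates this exchange. The expectation for compound 3 in this assay is nevertheless a move towards a lower number, of moderate size, likely beyond the scatter but not matching compound 2. The step from compound 1 to compound 3 is estimated as a 3.0-fold lower number from compound 1 to compound 3 (0.48 log units; beyond the scatter). For compound 3 the expected inhibition constant is 1500 nM, with a range from 500 nM to 4500 nM.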

Compound 3, inhibition constant: 490 nM
The estimate for compound 3 lay 3.1-fold (0.49 log units) above the measured number; measured number outside the range, below it.
By their numbers in this assay, from the lowest: compounds 3 and 2 (each within the scatter of the next); then compound 1.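

Among these compounds, on an aromatic carbon of the six-membered ring, para to a large group, methoxy in place of acetyl gives a 9.2-fold lower number from compound 1 to compound 3 (0.96 log units; beyond the scatter) in this assay, the first single change that can be read directly. Among the compounds shown here, the number at this position therefore depends on the group it carries and is not fixed by the shared core, with compound 3 at 490 nM against compound 1 at 4490 nM as the only pair to show it. The two groups have the same counts of hydrogen-bond donors and acceptors, while acetyl has 3 heavy atoms and a double bond outside aromatic rings and methoxy has 2 heavy atoms and no such bond, but no measured property of either group is available to account for the step.

One pair cannot tell whether the lower number comes from the arrival of methoxy or the departure of acetyl. Also open, on these data alone, is how a hydroxyl, an amine, a chlorine atom or a longer ether such as ethoxy would behave at this place, and whether methoxy would give a similar step on another carbon of the ring.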